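Methyl to Methoxy on a Weak Thienopyrimidine Series

The compounds below may be only part of what the source reports. "The series", "measured", "known", "first", "only" and "open" are said of these compounds alone.

Measured so far in a functional assay on L02 cells (Homo sapiens) for inhibition, read by Griess assay, with stated times of 1 h and 24 h; a higher number here means a weaker inhibitor, a lower number a stronger inhibitor:
Compound 1, `COc1cc(/C=C/c2nc(Nc3ccc(C)cc3)c3sccc3n2)cc(OC)c1OC`, gives a limit of < 40000 nM.
Compound 2, `COc1ccc(Nc2nc(/C=C/c3cc(OC)c(OC)c(OC)c3)nc3ccsc23)cc1`, gives 279000 nM.
Compound 3, `COc1cc(/C=C/c2nc(NCc3ccc(C)cc3)c3sccc3n2)cc(OC)c1OC`, gives a limit of > 1000000 nM.

The change from compound 1 to compound 2 is methoxy in place of methyl on an aromatic carbon. It gives an at least 6.9-fold higher number from compound 1 to compound 2 (0.84 log units; beyond the scatter). The two cores differ by 4-methylbenzyl in place of 4-methylphenyl on a nitrogen on an aromatic ring, and that change gives an at least 25-fold higher number from compound 1 to compound 3 (1.39 log units; beyond the scatter). Between compound 2 and compound 3 the change gives an at least 3.5-fold higher number from compound 2 to compound 3 (0.55 log units; beyond the scatter). The value of compound 1 is a limit, (the limit of < 40000 nM in this assay, at which 1 of the 3 values shown sits). The value of compound 3 is also a limit, (the limit of > 1000000 nM in this assay, at which 1 of the 3 values shown sits).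

Compound 4, `COc1ccc(CNc2nc(/C=C/c3cc(OC)c(OC)c(OC)c3)nc3ccsc23)cc1`, is not yet measured. It differs from compound 3 by methoxy in place of methyl on an aromatic carbon, the same change as that between compound 1 and compound 2. Since that change gave an at least 6.9-fold higher number from compound 1 to compound 2 (0.84 log units; beyond the scatter), compound 4 is expected to sit at or beyond the limit where compound 3 already stands, and the expected step is a step that the limit leaves unreadable from compound 3 to compound 4. The estimate for compound 4 in this assay is 2000000 nM, within 800000 nM to 8000000 nM.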

Compound 4, half-maximal inhibitory concentration: > 1000000 nM
Compound 4: no number, only a limit; the forecaster's own chance of this, stated with the estimate: 90%; the middle value is on the limit's open side.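

In this assay compound 4 gives > 1000000 nM, a limit of the assay and not a number. Compound 3 also stands at a limit, so the step from methyl to methoxy on this core cannot be read, and the change seen on the core of compound 1, an at least 6.9-fold higher number from compound 1 to compound 2 (0.84 log units; beyond the scatter), is neither confirmed nor contradicted here: the limit of > 1000000 nM in this assay, at which 2 of the 4 values shown sit. What can be read concerns the group on the nitrogen, where 4-methoxybenzyl in place of 4-methoxyphenyl gives an at least 3.5-fold higher number from compound 2 to compound 4 (0.55 log units; beyond the scatter), and 4-methoxybenzyl in place of 4-methylphenyl gives an at least 25-fold higher number from compound 1 to compound 4 (1.39 log units; beyond the scatter), so methoxy on the benzyl group did not bring compound 4 inside the limit of this assay.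

On these data alone, the true values of compound 3 and compound 4 remain open, so it is unknown whether methoxy shifts this core in the same direction at all. Also open, as far as these compounds go, is how a chlorine or a carboxylic acid on that aromatic carbon, or a longer chain than benzyl on the nitrogen, would read.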